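From Compound 1 to Compound 4: One Group Exchanged

The source may hold more compounds than are shown below. What is called first, only, known or untested is meant among the compounds shown, and "the series" means these compounds.

Going by the values given here, in an ADME assay on microsomes from liver (Homo sapiens) for metabolic stability, read by LC-MS, with a stated time of 10 min, tested at 0.5 uM (on this read-out higher numbers stand for a more stable compound and lower numbers for a less stable compound), three compounds have numbers so far. Compound 1 `c1ccc2c(c1)CN[C@H](CN(CCCN1CCNCC1)[C@H]1CCCc3cccnc31)C2` gives 99%, the highest of the three. Compound 2 `c1ccc2c(c1)CN[C@@H](CN(CC[C@@H]1CCCNC1)[C@H]1CCCc3cccnc31)C2` gives 75% and compound 3 `CN1CCN(CCCN(C[C@H]2Cc3ccccc3CN2C)[C@H]2CCCc3cccnc32)CC1` gives 60%. Both of these numbers lie lower than that of compound 1 by more than the usual scatter of repeated measurements.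

Compound 4 `c1cnc2c(c1)CCC[C@@H]2N(CCCN1CCNCC1)Cc1nc2ccccc2[nH]1` has not yet been measured. It keeps the rest of compound 1 and exchanges one group: 1H-benzimidazol-2-yl in place of 1,2,3,4-tetrahydroisoquinolin-3-yl on a saturated chain carbon bound to an amine nitrogen. In words, 1H-benzimidazol-2-yl stands in place of 1,2,3,4-tetrahydroisoquinolin-3-yl on a saturated chain carbon bound to an amine nitrogen.

Among the compounds with values here, no two measured compounds differ in just one place, so the data show no direct precedent for this exchange. In this assay a moderate step down is expected, probably beyond the scatter. Compound 1 at 99% has almost no room to rise, and compound 3 at 60% shows how much lower a related structure can sit. The estimated step is a number 27 percentage points lower from compound 1 to compound 4 (beyond the scatter). Compound 4 is expected to give 72%, within an estimated range from 48% to 93%.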

Compound 4, percent of the compound remaining: 63%
Estimate against measurement, compound 4: 9 percentage points above, and the stated range covers the measured number.
By their numbers in this assay, from the lowest: compounds 3 and 4 (each within the scatter of the next); then compound 2; then compound 1.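

In this assay, going by these compounds alone, the exchange of the one group gives a number 36 percentage points lower from compound 1 to compound 4 (beyond the scatter), the first step here that can be read for a change in a single place, and it shows that the group at this position can by itself move the number by a large amount. The printed counts of hydrogen-bond donors and acceptors are the same for the two groups, and neither carries a net charge, so those counts do not separate them; they do differ in heavy atoms, in the second ring, which is six-membered and non-aromatic in the group that leaves and five-membered and aromatic in the one that enters, and in the defined stereocentre, which only the leaving group has. No measurement shown tells which of these differences lies behind the fall, or why it occurs.

On these data alone, it remains open whether a plain phenyl group or a piperidin-2-yl group at this place would stay closer to compound 1 or fall as far as compound 4. As far as these compounds go, it is also open whether the same exchange would give a step of similar size on a core carrying a different chain in place of the piperazine-bearing propyl chain.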